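A few compounds are considered here, and "the series" means these few. Any claim that something is new, unique, unknown or untested is made for them only; others in the source may bear on it.

Compound 1 `CC1CCCN1CCCOc1ccc2c(c1)C(=O)N(C)CC2` gives 26 nM in an assay on cerebellum for displacement of a labelled ligand from histamine H1 receptor (Cavia porcellus), read by scintillation counting, with a stated time of 60 min; on this read-out higher numbers stand for weaker inhibition and lower numbers for stronger inhibition. Compound 2 `CN1CCc2ccc(OCCCN3CCC(=O)CC3)cc2C1=O` gives 176 nM.

On this assay compound 2 holds the higher of the two numbers, with a 6.8-fold higher number from compound 1 to compound 2 (0.83 log units; beyond the scatter) separating the pair. Compound 3 `CC1CCCCN1CCCOc1ccc2c(c1)C(=O)N(C)CC2` has not yet been measured; it differs from compound 2 in one place: 2-methylpiperidin-1-yl in place of 4-oxopiperidin-1-yl on a saturated chain carbon, three bonds along the chain from an oxygen on an aromatic ring. Going by the values given here, the one measured step that bears on this change is the move that brought in the oxo-bearing ring, a 6.8-fold higher number from compound 1 to compound 2 (0.83 log units; beyond the scatter). Swapping that ring for a methyl-bearing one resembles undoing that move, so a return toward the lower number is expected: a 5.9-fold lower number from compound 2 to compound 3 (0.77 log units; beyond the scatter). Compound 3 is therefore estimated at 30 nM, within 10 nM to 90 nM.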

Compound 3, inhibition constant: 165 nM
Beside the measured number, compound 3's estimate is 5.5-fold (0.74 log units) below it, and the stated range ends below it.
By their numbers in this assay, from the lowest: compound 1; then compounds 3 and 2 (each within the scatter of the next).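

In this assay, putting 2-methylpiperidin-1-yl in place of 4-oxopiperidin-1-yl gives a 1.1-fold lower number from compound 2 to compound 3 (0.03 log units; within the scatter), so at this position the methyl-bearing ring and the oxo-bearing ring cannot be told apart. Shrinking nothing else, the change from 2-methylpyrrolidin-1-yl to 2-methylpiperidin-1-yl gives a 6.3-fold higher number from compound 1 to compound 3 (0.80 log units; beyond the scatter), which shows that a methyl group alone does not keep the low number: among these three compounds, both six-membered rings stand apart from the pyrrolidine ring. Nothing available explains this difference. Still open, on these data alone, is whether the methyl group matters on the pyrrolidine ring, which plain pyrrolidin-1-yl would test, and how an open-chain amine such as dimethylamino would compare at this position.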